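A Fourth Benzamide in a Series Without Measurable Inhibition

A few compounds are considered here, and "the series" means these few. Any claim that something is new, unique, unknown or untested is made for them only; others in the source may bear on it.

Compound 3 `O=C(Nc1ccc(Sc2nc3ccccc3s2)cc1)c1ccccc1` carries a plain phenyl on the carbonyl carbon of its amide. In an assay on isolated protein for inhibition of thiosulfate sulfurtransferase (Homo sapiens), with a stated time of 60 min, in the absence of a further agent (a lower number here means a stronger inhibitor, a higher number a weaker inhibitor), compound 3 gives only a limit, > 100000 nM, and no number. Compound 1 `COc1ccc(Br)cc1C(=O)Nc1ccc(Sc2nc3ccccc3s2)cc1` bears a 5-bromo-2-methoxyphenyl at the same position. In this assay compound 1 likewise stops at a limit, > 100000 nM. Compound 2 `O=C(Nc1ccc(Sc2nc3ccccc3s2)cc1)c1cc(Br)cc(Br)c1` has a 3,5-dibromophenyl there. In this assay compound 2 also reaches only a limit, > 100000 nM. Accordingly the three steps among them cannot be read: a step that the two limits leave unreadable from compound 1 to compound 2, a step that the two limits leave unreadable from compound 1 to compound 3 and a step that the two limits leave unreadable from compound 2 to compound 3 are all hidden by the limits. What the set does show is the limit of > 100000 nM in this assay, at which 3 of the 3 values shown sit.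

Compound 4 `COc1c(Br)cccc1C(=O)Nc1ccc(Sc2nc3ccccc3s2)cc1` differs from compound 3 by a group of 9 heavy atoms (7 carbon, 1 oxygen, 1 bromine; one six-membered aromatic ring of carbon only) in place of a group of 6 heavy atoms (6 carbon; one six-membered aromatic ring of carbon only), on a carbonyl carbon. Among the measured compounds shown here, every measured step touching this position is unreadable, so no direction can be drawn from them; the only evidence is that all three measured aryl variants sit at the limit. Compound 4 is therefore expected to show no step beyond the scatter, a step that the limit leaves unreadable from compound 3 to compound 4, and most probably another limit. For compound 4 in this assay the estimate is 150000 nM, with a range from 50000 nM to 500000 nM.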

Compound 4, half-maximal inhibitory concentration: > 100000 nM
Compound 4: no number, only a limit (the forecaster's own chance of this, stated with the estimate: 90%); the middle value does not contradict the limit.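

In this assay compound 4 gives only a limit, > 100000 nM, and no number. None of the steps linking compound 4 to compound 1, compound 2 or compound 3 can be read, and the set shows one thing only: the limit of > 100000 nM in this assay, at which 4 of the 4 values shown sit. The compounds shown leave open how far any of the four lies beyond that limit, and whether any group on the carbonyl carbon gives a measurable value.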